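The source may hold more compounds than are shown below. What is called first, only, known or untested is meant among the compounds shown, and "the series" means these compounds.

Compound 3 `CC(/C=N/Nc1ccc([N+](=O)[O-])cc1)=N\NC(=O)c1ccccc1O` gives 1640 nM in a functional assay on cells (Splenocyte, Mus musculus, strain BALB/c) for inhibition, read by scintillation counting and thymidine incorporation, with a stated time of 72 h (on this read-out lower numbers stand for stronger inhibition and higher numbers for weaker inhibition), the lowest of the two numbers recorded there. Its nearest neighbour is compound 1 `CC(/C=N/N(C)c1ccc([N+](=O)[O-])cc1)=N\NC(=O)c1ccccc1O`, which gives 3120 nM; the two are joined by a 1.9-fold lower number from compound 1 to compound 3 (0.28 log units; within the scatter), so they cannot be told apart. Compound 2 `COc1ccc(C(=O)N/N=C(C)/C=N/Nc2ccc([N+](=O)[O-])cc2)cc1` reaches only the limit of this assay, > 12000 nM. The change on the carbonyl carbon brought an at least 7.3-fold lower number from compound 2 to compound 3 (0.86 log units; beyond the scatter), the one step of real size among these compounds.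

Compound 4 `CC(/C=N/Nc1ccc([N+](=O)[O-])cc1)=N\NC(=O)c1ccccc1Oc1ccccc1` has not been measured. It differs from compound 3 by phenyl in place of hydrogen on an oxygen on an aromatic ring. Within the data shown here, no measured pair makes this exact change. The step from compound 2 to compound 3 is the closest guide: it too alters the ring on the carbonyl carbon, exchanging a methoxy-bearing ring for a hydroxy-bearing one, and it favoured the free hydroxy. Turning that hydroxy into a phenoxy points the other way, so a weakening is expected. Compound 4 is estimated at 6000 nM, between 2000 nM and 20000 nM, which amounts to an expected 3.7-fold higher number from compound 3 to compound 4 (0.56 log units; beyond the scatter).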

Compound 4, half-maximal inhibitory concentration: > 12000 nM
Compound 4 gave a limit, no number; the forecaster's own chance of this, stated with the estimate: 25%; middle value at least 2.0-fold (0.30 log units) from the limit.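

In this assay, the replacement of hydroxy by phenoxy brought an at least 7.3-fold higher number from compound 3 to compound 4 (0.86 log units; beyond the scatter). The step from compound 2 to compound 3 exchanged 4-methoxyphenyl for 2-hydroxyphenyl and so altered the group on the carbonyl carbon as a whole, whereas this step changes only what sits on the oxygen, and it shows that the activity of compound 3 does not survive phenyl there. Compound 4 gives a limit and not a number, so the full size of this step stays unknown: the limit of > 12000 nM in this assay, at which 2 of the 4 values shown sit.

The compounds shown leave open whether the loss belongs to phenyl in particular or would follow from any group on that oxygen, such as acetyl. They also leave open what an amine in place of the hydroxy would do.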